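Compound 4: from benzoyl to phenyl

A few compounds are considered here, and "the series" means these few. Any claim that something is new, unique, unknown or untested is made for them only; others in the source may bear on it.

Measured so far in a physicochemical assay for lipophilicity, read by HPLC, measured as chromatographic lipophilicity, at pH 7.4; a lower number here means a more polar compound, a higher number a more lipophilic compound:
Compound 1 `O=C(c1ccccc1)N1CCC(C(=O)N2N=CCC2c2ccccc2)CC1`: 4.4
Compound 2 `C[C@@H]1C=NN(C(=O)C(C)(C)C)[C@@H]1c1ccccc1`: 6.5
Compound 3 `CC(C)(C)C(=O)N1N=CCC1c1ccccn1`: 3.5

Compound 1 at 4.4 stands second highest of the three. Compound 3 at 3.5 lies below it and compound 2 at 6.5 lies above it, both gaps beyond the scatter. Compound 4 `O=C(C1CCN(c2ccccc2)CC1)N1N=CCC1c1ccccc1` has not yet been measured. It differs from compound 1 by phenyl in place of benzoyl on an amine nitrogen in a ring and nothing else. For the measured compounds named here, no measured pair shows a comparable change, so the expectation rests on judgement alone. An upward move in this assay beyond the scatter is expected, an estimated a number 1.00 log units higher from compound 1 to compound 4 (beyond the scatter) in size. For compound 4 the estimated value is 5.4 with an expected range from 4.8 to 6 on this scale.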

Compound 4, distribution coefficient: 6.3
Compound 4: middle estimate off by 0.90 log units, on the low side; the measured number lies above the stated range.
By their numbers in this assay, from the lowest: compound 3; then compound 1; then compounds 4 and 2 (each within the scatter of the next).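

In this assay, phenyl in place of benzoyl on the amine nitrogen in the six-membered non-aromatic ring gives a large step, a number 1.90 log units higher from compound 1 to compound 4 (beyond the scatter) and this is the first change at a single place that can be read among these compounds. Benzoyl carries a hydrogen-bond acceptor and phenyl carries none, but this one step cannot show whether that difference matters. Nothing measured here accounts for the size of the step. From the compounds shown here alone, whether a benzyl or an acetyl group on that nitrogen would fall nearer phenyl or benzoyl remains open. So does whether the step would hold on a core other than that of compound 1.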